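Rearranging the acyloxyalkyl carbamate: compound 3 to compound 4

This account rests on a few compounds, and the source may have more. Where it says the series, first, only, none or still open, it means among the compounds named here.

Compound 3 `CC(OC(=O)C(C)C)OC(=O)N1CCN(C(=O)c2nc(Nc3cc(C4CC4)[nH]n3)c3cc(Cl)ccc3n2)C[C@H]1C` stands lowest of the three measured compounds in an ADME assay on S9 fraction from liver (Rattus norvegicus), read by LC-MS, with a stated time of 60 min, at 37 degrees C (a lower number here means that less of the compound is left, a higher number that more of the compound is left), giving 11%. Compound 1 `CCCCCOC(=O)N1CCN(C(=O)c2nc(Nc3cc(C4CC4)[nH]n3)c3cc(Cl)ccc3n2)C[C@H]1C` gives 63.9% and compound 2 `COC(=O)N1CCN(C(=O)c2nc(Nc3cc(C4CC4)[nH]n3)c3cc(Cl)ccc3n2)C[C@H]1C` gives 34.2%. Compound 4 `C[C@@H]1CN(C(=O)c2nc(Nc3cc(C4CC4)[nH]n3)c3cc(Cl)ccc3n2)CCN1C(=O)OCOC(=O)C(C)(C)C` differs from compound 3 by (((tert-butyl)carbonyl)oxy)methyl in place of 1-((isopropylcarbonyl)oxy)ethyl on an oxygen next to a carbonyl group. Both acyloxyalkyl carbamates so far sit far below the simple esters: a number 52.9 percentage points lower from compound 1 to compound 3 (beyond the scatter) and a number 23.2 percentage points lower from compound 2 to compound 3 (beyond the scatter). Within the data shown here, no measured step compares two such groups with each other, so compound 4 is expected to stay near compound 3, with a step of a number 4 percentage points higher from compound 3 to compound 4 (within the scatter) expected at most. The estimate for compound 4 in this assay is therefore 15%, expected between 3% and 35%.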

Compound 4, percent of the compound remaining: 47%
Estimate against measurement, compound 4: 32 percentage points below, and the stated range ends below it.
By their numbers in this assay, from the lowest: compound 3; then compound 2; then compound 4; then compound 1.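

In this assay, the two acyloxyalkyl carbamates do not behave alike, although they have the same atoms: (((tert-butyl)carbonyl)oxy)methyl in place of 1-((isopropylcarbonyl)oxy)ethyl gives a number 36 percentage points higher from compound 3 to compound 4 (beyond the scatter). The carbamate no longer falls below both simple esters, with a number 12.8 percentage points higher from compound 2 to compound 4 (beyond the scatter) but still a number 16.9 percentage points lower from compound 1 to compound 4 (beyond the scatter). Nothing available explains this difference.

The compounds shown leave open whether the acyl part or the alkyl part carries the step. ((Isopropylcarbonyl)oxy)methyl and 1-(((tert-butyl)carbonyl)oxy)ethyl are the groups that would separate the two.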